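The compounds below may be only part of what the source reports. "The series", "measured", "known", "first", "only" and "open" are said of these compounds alone.

Measured compounds:

Compound 1, `O=C(Cn1cc(-c2ccc(F)cc2)nn1)Nc1nccs1`, in a functional assay on BMDM cells (Mus musculus, strain C57BL/6) for inhibition, with a stated time of 2 days (a lower number here means a stronger inhibitor, a higher number a weaker inhibitor), gives 190 nM.
Compound 2, `O=C(Cn1cc(-c2cccc(Cl)c2)nn1)Nc1nccs1`, in this assay gives only a limit of the assay, > 30000 nM.

Among the compounds with values here, compound 1 stands as the only actual number here, the other value being a limit. Within the data shown here, the single measured step is an at least 150-fold higher number from compound 1 to compound 2 (2.19 log units; beyond the scatter), and what it shows is simply that one of the two values sits at the limit, (the limit of > 30000 nM in this assay, at which 1 of the 2 values shown sits). That step exchanges the whole substituted phenyl group, so it does not directly test the change under consideration.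

Compound 3, `C#Cc1ccc(-c2cn(CC(=O)Nc3nccs3)nn2)cc1`, differs from compound 1 by ethynyl in place of fluoro on an aromatic carbon. Among the measured compounds shown here, no measured step exchanges one group on this ring for another at the same place, so there is no measured precedent of matching shape. The expectation therefore rests on the untouched remainder of the shared core, and the step is expected to be a 1.1-fold higher number from compound 1 to compound 3 (0.02 log units; within the scatter), not beyond the scatter in either direction. Compound 3 is accordingly estimated at 200 nM in this assay, with a range from 50 nM to 1000 nM.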

Compound 3, half-maximal inhibitory concentration: > 30000 nM
Compound 3: a limit, no number; the forecaster's own chance of this, stated with the estimate: 10%; middle value at least 150-fold (2.17 log units) away from the limit.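

In this assay compound 3 gives > 30000 nM which is a limit of the assay and not a number. Unlike the earlier step, which exchanged the whole substituted phenyl group, this one changes a single group on an aromatic carbon para to a large group, and the result is an at least 150-fold higher number from compound 1 to compound 3 (2.19 log units; beyond the scatter) so the shared core alone does not secure the activity of compound 1, and this one exchange at this place is enough to lose it. How large the loss really is cannot be told, because compound 2 and compound 3 both rest at the same end of the measurable range: the limit of > 30000 nM in this assay, at which 2 of the 3 values shown sit.

The compounds shown leave open whether any other group on this carbon, such as methyl, methoxy or an amine, would keep a measurable value in this assay. They also leave open whether a plain hydrogen in place of fluoro would hold up as well as compound 1 does, and so whether fluoro itself is needed or ethynyl alone is the problem.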